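Shortening the Propyl Chain on a Weakly Active Core

The compounds below may be only part of what the source reports. "The series", "measured", "known", "first", "only" and "open" are said of these compounds alone.

Of the compounds shown here, two of one shared core have been tested in a functional assay for inhibition, with Homo sapiens as the target; a lower number here means a stronger inhibitor, a higher number a weaker inhibitor. Compound 1 `CCCc1nc(C)c2c(-c3ccccc3)nnc(SC)n12` gives > 48000 nM, which is only a limit of the assay and not a measured number. Compound 2 `CCCc1nc(C)c2c(C)nnc(SC)n12` gives > 48000 nM, again only a limit. The step that the two limits leave unreadable from compound 1 to compound 2 therefore cannot be read, because both values sit at the limit of > 48000 nM in this assay, at which 2 of the 2 values shown sit. So compound 2 stands only at a limit in this assay, with no number to compare. Compound 3 `CSc1nnc(C)c2c(C)nc(C)n12` is not yet measured; it differs from compound 2 by hydrogen in place of ethyl on a saturated chain carbon bound to an aromatic carbon. Among the measured compounds shown here, no measured step touches this chain, and the single measured step is itself unreadable, so nothing points to a shift beyond the scatter in this assay . Compound 3 is therefore expected to give about 60000 nM, within 20000 nM to 200000 nM, most likely again reported only as a limit. The step that the limit leaves unreadable from compound 2 to compound 3 that this estimate means is expected to be no change beyond the scatter.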

Compound 3, half-maximal inhibitory concentration: > 48000 nM
Compound 3: only a limit was reported; the forecaster's own chance of this, stated with the estimate: 85%; the middle value does not contradict the limit.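

Compound 3, like compound 2, is reported only as a limit and not as a number, so the step between them cannot be read: the limit of > 48000 nM in this assay, at which 3 of the 3 values shown sit.

The compounds shown leave open whether shortening propyl to methyl changes inhibition at all in this assay.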